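The compounds below may be only part of what the source reports. "The series", "measured", "known", "first", "only" and "open" are said of these compounds alone.

Compound 1, `CC(C)CCCN(C(=O)[C@@H]1C[C@H]1c1ccccc1)c1ccc(-c2ccccc2)cc1`, is the starting point in a functional assay for agonist activity at G protein-coupled receptor 88 (Homo sapiens), read by HTRF and cAMP accumulation; on this read-out higher numbers stand for an effect only at larger amounts of compound and lower numbers for an effect already at smaller amounts. In this assay compound 1 returns only a limit, > 100 nM, and no number. Compound 2, `CC(C)[C@H](N)CN(C(=O)[C@@H]1C[C@H]1c1ccccc1)c1ccc(-c2ccccc2)cc1`, carries 1-amino-2-methylpropyl in place of isopentyl on the saturated chain carbon bound to the amide-type nitrogen, and in this assay compound 2 gives 1.1 nM. Going by the values given here, that is the only number in the set; the other value sits at the limit (the limit of > 100 nM in this assay, at which 1 of the 2 values shown sits), and the step of an at least 90-fold lower number from compound 1 to compound 2 (1.95 log units; beyond the scatter) is correspondingly large. Compound 3, `CO[C@H](C)[C@H](N)CN(C(=O)[C@@H]1C[C@H]1c1ccccc1)c1ccc(-c2ccccc2)cc1`, keeps the amine of compound 2 and differs from it by 1-methoxyethyl in place of isopropyl on a saturated chain carbon bound to an amine nitrogen and a saturated chain carbon. Among the compounds with values here, the only measured step concerns the arrival of the amine, not an exchange on the chain beyond it, so it bears on this change only loosely. The expected step in this assay is therefore small, a 1.8-fold higher number from compound 2 to compound 3 (0.26 log units; within the scatter), and compound 3 is estimated at 2 nM, within 0.6 nM to 8 nM.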

Compound 3, half-maximal effective concentration: 0.68 nM
For compound 3 the middle estimate is 2.9-fold (0.47 log units) above the measured one, and the stated range covers the measured number.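

In this assay, 1-methoxyethyl in place of isopropyl on the saturated chain carbon bound to an amine nitrogen and a saturated chain carbon gives a 1.6-fold lower number from compound 2 to compound 3 (0.21 log units; within the scatter), so the two compounds stand level and this position accepts the methoxy oxygen and the defined stereocentre that enter with it. The large step seen with 1-amino-2-methylpropyl recurs with 1-amino-2-methoxypropyl in place of isopentyl, as an at least 140-fold lower number from compound 1 to compound 3 (2.16 log units; beyond the scatter). This second step starts from a limit of compound 1, not a number, and so gives only a bound: the limit of > 100 nM in this assay, at which 1 of the 3 values shown sits.

As far as these compounds go, how this position would respond to 1-hydroxyethyl, to a longer ethoxy-bearing chain or to the other configuration at the new stereocentre remains open. From the compounds shown here alone, whether a hydroxyl in place of the amine would hold such a low number also stays open.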